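This account rests on a few compounds, and the source may have more. Where it says the series, first, only, none or still open, it means among the compounds named here.

In a functional assay on Caco-2 cells (Homo sapiens) for inhibition, read by MTT assay, with a stated time of 48 h, tested at 10 uM (on this read-out higher numbers stand for more inhibition of growth at the one concentration tested and lower numbers for less inhibition of growth), compound 1 (`Cc1cc(=O)c2c(O)c(CN3CCCC3)c(O)c([C@H]3CCN(C)C[C@H]3O)c2o1`) gives 22% and compound 2 (`Cc1cc(=O)c2c(O)c(CN3CCC(Cc4ccccc4)CC3)c(O)c([C@H]3CCN(C)C[C@H]3O)c2o1`) gives 21% while compound 3 (`Cc1cc(=O)c2c(O)c(CN(C(C)C)C(C)C)c(O)c([C@H]3CCN(C)C[C@H]3O)c2o1`) gives 22% on the same read-out. Compound 3 thus stands level with compound 1 and within the scatter of compound 2, and the three values show no separation.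

The next change leads to compound 4 (`Cc1cc(=O)c2c(O)c(CN3CCCCC3)c(O)c([C@H]3CCN(C)C[C@H]3O)c2o1`), with piperidin-1-yl in place of diisopropylamino on a saturated chain carbon bound to an aromatic carbon.

For the measured compounds named here, one measured step bears directly on this place (no change at the digits printed from compound 1 to compound 3 (within the scatter)), with diisopropylamino in place of pyrrolidin-1-yl. Since that step stays within the scatter and compound 2 also gives 21% in this series, no step beyond the scatter is expected in this assay in either direction.

The expected size of the change is small (no change at the digits printed from compound 3 to compound 4 (within the scatter)) and is estimated to remain within the scatter. Compound 4 is estimated at 22% with an expected range of 12% to 32% in this measurement.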

Compound 4, percent growth inhibition at one concentration: 22%
The estimate for compound 4 equals the measured number at the digits printed, within the range that was stated.
By their numbers in this assay, from the lowest: compounds 2, 1, 3 and 4 (each within the scatter of the next).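

In this assay, the piperidin-1-yl ring in place of the open-chain diisopropylamino on this saturated chain carbon reads no change at the digits printed from compound 3 to compound 4 (within the scatter), and piperidin-1-yl in place of pyrrolidin-1-yl reads no change at the digits printed from compound 1 to compound 4 (within the scatter), so neither ring against open chain nor this difference in ring size separates the compounds here. Hydrogen in place of benzyl on a saturated ring carbon of the piperidin-1-yl group reads a number 1 percentage points higher from compound 2 to compound 4 (within the scatter), so that substituent does not separate the pair either. No measurement is available to explain this flat picture.

Still open, as far as these compounds go, is whether a morpholin-4-yl, a piperazin-1-yl or a carboxylic acid at this place would separate from these values. Also open, from the compounds shown here alone, is whether the four compounds stay level at other concentrations.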